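Phenoxy in place of pyridylethoxy: expected cytotoxicity

The source may report more compounds than this note shows. Statements on the series, on what has been measured and on what is new or still open speak of the compounds shown alone.

In an ADME assay on PC-3 cells (Homo sapiens) for cytotoxicity, read by WST assay, tested at 100 uM (on this read-out higher numbers stand for more inhibition at the one concentration tested (going by the name of the read-out) and lower numbers for less inhibition), compound 3 `O=C(Nc1cccc(OCCc2ccccn2)c1)C1CCCN(C(=O)c2cc(C(F)(F)F)cc(C(F)(F)F)c2)C1` gives 5%, the highest of three numbers, yet within the usual scatter of compound 1 `CC(C)(C)OC(=O)c1cccc(NC(=O)C2CCCN(C(=O)c3cc(C(F)(F)F)cc(C(F)(F)F)c3)C2)c1` at 0% and of compound 2 `CSc1cccc(NC(=O)C2CCCN(C(=O)c3cc(C(F)(F)F)cc(C(F)(F)F)c3)C2)c1` at 0%. All three share the same core and differ only in one group on the aromatic ring; none shows meaningful inhibition of these cells. Compound 4 `O=C(Nc1cccc(Oc2ccccc2)c1)C1CCCN(C(=O)c2cc(C(F)(F)F)cc(C(F)(F)F)c2)C1` differs from compound 3 in one place: phenyl in place of 2-(pyridin-2-yl)ethyl on an oxygen on an aromatic ring. Earlier changes at this same aromatic position, a number 5 percentage points higher from compound 1 to compound 3 (within the scatter) and a number 5 percentage points higher from compound 2 to compound 3 (within the scatter), stayed within the scatter, as did no change at the digits printed from compound 1 to compound 2 (within the scatter). So no step beyond the scatter is expected in this assay . Compound 4 is expected to give about 4%, between 0% and 15%. The expected step is therefore a number 1 percentage points lower from compound 3 to compound 4 (within the scatter), nothing beyond scatter.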

Compound 4, a percentage reported as inhibition, at one concentration (the size of the read-out at that concentration, not a potency): 1%
For compound 4 the middle estimate is 3 percentage points above the measured one; the range from low to high includes it.
By their numbers in this assay, from the lowest: compounds 1, 2, 4 and 3 (each within the scatter of the next).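

Putting phenyl on this oxygen in place of 2-(pyridin-2-yl)ethyl gives, in this assay, a number 4 percentage points lower from compound 3 to compound 4 (within the scatter). Phenoxy also matches the other two groups on this aromatic carbon, with a number 1 percentage points higher from compound 2 to compound 4 (within the scatter) and a number 1 percentage points higher from compound 1 to compound 4 (within the scatter), so all four groups shown here read alike. Nothing available explains this flat result. Going by these compounds, whether an amine or a carboxylic acid at this position would move the number beyond the scatter remains open, as does the effect of changes elsewhere on the shared core.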